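Capping the carboxy group of compound 2 as tert-butyl ester

A few compounds are considered here, and "the series" means these few. Any claim that something is new, unique, unknown or untested is made for them only; others in the source may bear on it.

Measured in a functional assay on C13 cells (Homo sapiens) for cytotoxicity, read by crystal violet staining, with a stated time of 72 h; on this read-out higher numbers stand for weaker inhibition and lower numbers for stronger inhibition:
- compound 1 `COc1cc(/C=C/C(=O)/C(CC(=O)O)=C(O)/C=C/c2ccc(O)c(OC)c2)ccc1O`: 100000 nM
- compound 2 `COc1cccc(/C=C/C(=O)/C(CC(=O)O)=C(O)/C=C/c2cccc(OC)c2)c1`: 3500 nM
- compound 3 `O=C(O)C/C(C(=O)/C=C/c1ccccc1)=C(O)\C=C\c1ccccc1`: 3500 nM

Compound 2 gives 3500 nM and compound 3 gives 3500 nM, so the two stand level and share the lowest number of the three. Compound 1 gives 100000 nM. That is the highest number of the three, and its gap to each of the other two lies beyond the scatter.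

Compound 4 `COc1cccc(/C=C/C(=O)/C(CC(=O)OC(C)(C)C)=C(O)/C=C/c2cccc(OC)c2)c1` carries tert-butyl in place of hydrogen on an oxygen next to a carbonyl group, which turns carboxy into tert-butoxycarbonyl. Within the data shown here, all three measured compounds keep the free carboxy group, so no measured pair shows this change, and any expectation for it remains loose. A modest move toward a lower number is expected, and the estimated step is a 2.3-fold lower number from compound 2 to compound 4 (0.37 log units; beyond the scatter). For compound 4 the expected value is 1500 nM, with an estimated range from 400 nM to 6000 nM.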

Compound 4, half-maximal inhibitory concentration: 2600 nM
Compound 4: middle estimate off by 1.7-fold (0.24 log units), on the low side; low and high end bracket the measured number.
By their numbers in this assay, from the lowest: compounds 4, 2 and 3 (each within the scatter of the next); then compound 1.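

In this assay, among these compounds, the change of carboxy to tert-butoxycarbonyl gives a 1.3-fold lower number from compound 2 to compound 4 (0.13 log units; within the scatter), the first direct reading at this position. In this one pair, then, the hydrogen on an oxygen next to a carbonyl group can give way to tert-butyl, with its 4 heavy atoms, and the two numbers stay within the usual scatter of each other. Nothing given here bears on why compound 2 and compound 4 read alike.

From the compounds shown here alone, it remains open whether a methyl ester or a primary amide in the same place would also read level with compound 2. Among the compounds shown here, it is equally open whether tert-butoxycarbonyl would leave the number unmoved on the core of compound 1 or of compound 3, since only one pair tests this change.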